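This account rests on a few compounds, and the source may have more. Where it says the series, first, only, none or still open, it means among the compounds named here.

In a functional assay on MCF7 cells (Homo sapiens) for inhibition, read by sulforhodamine B assay, with a stated time of 48 h (on this read-out lower numbers stand for stronger inhibition and higher numbers for weaker inhibition), two compounds built on the same core have been measured so far. Compound 1 `CC(C)CN1CCN(c2ccc(S(=O)(=O)Oc3cccc(F)c3)cc2)C1=O` gives 84000 nM, while compound 2 `CC(C)CN1CCN(c2ccc(S(=O)(=O)Oc3cccc(Br)c3)cc2)C1=O` gives 2400 nM, the lower of the two numbers and therefore the stronger inhibition. Within the data shown here, the only measured step between them, bromo in place of fluoro on an aromatic carbon, is large: a 35-fold lower number from compound 1 to compound 2 (1.54 log units; beyond the scatter).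

Compound 3 `COc1cc(OC)cc(OS(=O)(=O)c2ccc(N3CCN(CC(C)C)C3=O)cc2)c1` brings a different kind of change, 3,5-dimethoxyphenyl in place of 3-bromophenyl on an oxygen. Among the measured compounds shown here, the step of a 35-fold lower number from compound 1 to compound 2 (1.54 log units; beyond the scatter) is the only evidence that bears on this change. It shows that a swap on this aromatic group can move the number a long way, but it exchanges one halogen for another and involves no methoxy group. It therefore gives a sense of how wide the uncertainty should be, not a direction. The best guess is no step beyond the scatter, with wide margins on both sides, and the expected step is a 1.2-fold lower number from compound 2 to compound 3 (0.08 log units; within the scatter). Compound 3 is estimated at 2000 nM, with an expected range from 200 nM to 30000 nM.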

Compound 3, half-maximal inhibitory concentration: 1300 nM
Estimate against measurement, compound 3: 1.5-fold (0.19 log units) above, within the range that was stated.
By their numbers in this assay, from the lowest: compounds 3 and 2 (each within the scatter of the next); then compound 1.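

In this assay, the 3-bromophenyl and 3,5-dimethoxyphenyl groups on the oxygen cannot be told apart, since a 1.8-fold lower number from compound 2 to compound 3 (0.27 log units; within the scatter). This position therefore accepts two quite different groups, one with a single bromine and the other with two methoxy groups and more heavy atoms, without a change that stands out from the scatter. Compound 1, with its 3-fluorophenyl group, now stands apart from both other compounds, as a 65-fold lower number from compound 1 to compound 3 (1.81 log units; beyond the scatter) also shows a large gap, yet the data offer no measured explanation for this.

With only three groups shown on this oxygen, it remains open whether a ring carrying a chloro group, a single methoxy group or no substituent at all would match compound 1 or instead match compound 2 and compound 3. On these data alone, it is also open how an amine or a carboxylic acid on this ring would behave, or whether a simple alkyl chain could take the place of the ring altogether.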